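From Hydroxy to Sulfanyl on the Shared Core

A few compounds are considered here, and "the series" means these few. Any claim that something is new, unique, unknown or untested is made for them only; others in the source may bear on it.

Measured so far:
compound 1 `CCC(CO)Nc1nc(NCc2ccccc2)c2nc(Cl)n(C(C)C)c2n1`: 54000 nM
compound 2 `CCC(CO)Nc1nc(NCc2ccccc2)c2nc(O)n(C(C)C)c2n1`: 65000 nM

In a functional assay on MCF7 cells (Homo sapiens) for cytotoxicity (on this read-out higher numbers stand for weaker inhibition and lower numbers for stronger inhibition), compound 2 gives 65000 nM and stands level with compound 1 within the scatter. The compound still to be measured is compound 3 `CCC(CO)Nc1nc(NCc2ccccc2)c2nc(S)n(C(C)C)c2n1` and it differs from compound 2 by one exchange: sulfanyl in place of hydroxy on an aromatic carbon so that sulfanyl takes the place of hydroxy on an aromatic carbon. Within the data shown here, one measured step bears on this carbon, the exchange of chloro for hydroxy, which gave a 1.2-fold higher number from compound 1 to compound 2 (0.08 log units; within the scatter) as its result. Among the measured compounds shown here, that is a single step, and no compound with sulfanyl has yet been measured. No step beyond the scatter is therefore expected in this assay here. The expected step is a 1.2-fold lower number from compound 2 to compound 3 (0.07 log units; within the scatter) and the margin stays wide. Compound 3 is estimated at 55000 nM (22000 nM to 110000 nM).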

Compound 3, half-maximal inhibitory concentration: 55000 nM
Beside the measured number, compound 3's estimate shows no gap at the digits printed; the measured number falls inside the stated range.
By their numbers in this assay, from the lowest: compounds 1, 3 and 2 (each within the scatter of the next).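

With sulfanyl on this aromatic carbon, this assay gives a 1.2-fold lower number from compound 2 to compound 3 (0.07 log units; within the scatter) and a 1.0-fold higher number from compound 1 to compound 3 (0.01 log units; within the scatter) as its two new steps, both within the scatter. Among these compounds, the earlier pair showed only that chloro and hydroxy stand level at this position between two ring nitrogen atoms, and the series now holds three groups on the same carbon, with no step among them that leaves the scatter. No evidence at hand accounts for this levelness.

The compounds shown leave open whether an amine, a carboxylic acid or a longer chain on this carbon would stand apart from these three groups. They also leave open whether the three would remain level if another group, such as a cyclopentyl ring, took the place of the isopropyl group.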